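Swapping a Methyl Ester for a Hydroxymethyl Group

The source may report more compounds than this note shows. Statements on the series, on what has been measured and on what is new or still open speak of the compounds shown alone.

Of the compounds shown here, two sharing one core have been measured in an assay on isolated protein for inhibition of Fatty-acid amide hydrolase 1 (Homo sapiens), read by fluorescence, with a stated time of 30 min; on this read-out higher numbers stand for weaker inhibition and lower numbers for stronger inhibition. Compound 1 `O=C(NC1CCCCC1)Oc1cccc(-c2cc(C(=O)NC3CCCCC3)nn2-c2ccccc2)c1` gives 288 nM in this assay, while compound 2 `COC(=O)c1cc(-c2cccc(OC(=O)NC3CCCCC3)c2)n(-c2ccccc2)n1` gives 18 nM. Within the data shown here, compound 2 stands lowest of the two numbers, and the single change separating them, methoxy in place of cyclohexylamino on a carbonyl carbon, produced a 16-fold lower number from compound 1 to compound 2 (1.20 log units; beyond the scatter), a large step.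

Compound 3 `O=C(NC1CCCCC1)Oc1cccc(-c2cc(CO)nn2-c2ccccc2)c1` differs from compound 2 in one place: hydroxymethyl in place of methoxycarbonyl on an aromatic carbon. This is again a change on the same arm of the core that was altered between compound 1 and compound 2, and once more the group that enters is smaller than the group that leaves. That earlier step is the only one that bears on the question, and it shows the position tolerates a shift from a bulky group to a small one with a strongly lower number. Among the measured compounds shown here, a hydroxymethyl group is, however, a different kind of small group, and no measured pair tests it directly.

For compound 3 a modest shift is expected, a 2.2-fold higher number from compound 2 to compound 3 (0.35 log units; beyond the scatter) in this assay. The estimated value for compound 3 is therefore 40 nM, with a plausible range from 10 nM to 160 nM.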

Compound 3, half-maximal inhibitory concentration: 462 nM
Beside the measured number, compound 3's estimate is 12-fold (1.06 log units) below it; measured number above the stated range.
By their numbers in this assay, from the lowest: compound 2; then compounds 1 and 3 (each within the scatter of the next).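

At this position on the five-membered aromatic ring, in this assay, hydroxymethyl in place of methoxycarbonyl gives a 26-fold higher number from compound 2 to compound 3 (1.41 log units; beyond the scatter), so a smaller group does not by itself bring a lower number here, as the step from compound 1 to compound 2 alone might have suggested. Among these compounds, the hydroxymethyl of compound 3 and the cyclohexylcarbamoyl of compound 1 are very different groups, yet the comparison gives a 1.6-fold higher number from compound 1 to compound 3 (0.21 log units; within the scatter), which leaves methoxycarbonyl in compound 2 as the only one of the three groups with a number set apart from the others, and means that the numbers do not follow group size across these three compounds. Nothing available here explains what sets methoxycarbonyl apart.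

The compounds shown leave open whether that low number belongs to the methyl ester specifically or would also appear with a close relative such as an ethyl ester, a carboxylic acid or a primary amide. A methoxymethyl group would also help, since it would show whether replacing the hydrogen of the hydroxymethyl group with a methyl group changes the number.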